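Chloro on compound 1: expected step

This account rests on a few compounds, and the source may have more. Where it says the series, first, only, none or still open, it means among the compounds named here.

In a functional assay on RAW264.7 cells (Mus musculus) for inhibition (a lower number here means a stronger inhibitor, a higher number a weaker inhibitor), compound 1 (`O=C1/C(=C/c2ccccc2)CCc2ccc(O)cc21`) gives 710 nM and compound 2 (`O=C1/C(=C/c2ccc(OC(F)(F)F)cc2)CCc2ccc(O)cc21`) gives 980 nM, so the two stand within the scatter of each other. Compound 3 (`O=C1/C(=C/c2cccc(Cl)c2)CCc2ccc(O)cc21`) differs from compound 1 by chloro in place of hydrogen on an aromatic carbon, meta to a large group. Among the measured compounds shown here, one measured step bears on this, a trifluoromethoxy replacement of hydrogen on an aromatic carbon: a 1.4-fold higher number from compound 1 to compound 2 (0.14 log units; within the scatter). A single step is thin evidence, and no shift beyond the scatter is expected. The expected step is a 1.1-fold lower number from compound 1 to compound 3 (0.04 log units; within the scatter). For compound 3 the estimate is 650 nM, with a range of 280 nM to 1500 nM.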

Compound 3, half-maximal inhibitory concentration: 210 nM
The estimate for compound 3 lay 3.1-fold (0.49 log units) above the measured number; measured number below the stated range.
By their numbers in this assay, from the lowest: compound 3; then compounds 1 and 2 (each within the scatter of the next).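

In this assay the step of a 3.4-fold lower number from compound 1 to compound 3 (0.53 log units; beyond the scatter) shows that chloro in place of hydrogen on an aromatic carbon, meta to a large group, can move the number beyond the scatter. The trifluoromethoxy step a 1.4-fold higher number from compound 1 to compound 2 (0.14 log units; within the scatter) stays within the scatter, so compound 3 is the only one here with a shift of that kind. Nothing at hand accounts for the shift.

From the compounds shown here alone, it remains open whether the shift belongs to chloro itself or to this place on the ring. Methyl, fluoro or an amine on the same carbon, and chloro on the other ring carbons, would separate the two.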